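This account rests on a few compounds, and the source may have more. Where it says the series, first, only, none or still open, it means among the compounds named here.

Of the compounds shown here, two have so far been measured in a physicochemical assay for lipophilicity, measured as octanol-water partition; a higher number here means a more lipophilic compound, a lower number a more polar compound. Compound 1, `CC(C)=CCC1=C(O)C(C(=O)C(C)C)=C(O)[C@](O)(CC=C(C)C)C1=O`, gives 2.92 in this assay. Compound 2, `CC(C)=CCC(=O)C1(O)C(O)=C(C(C)C)C(=O)C1CC=C(C)C`, gives 2.05. Compound 2 thus holds the lower of the two numbers, with compound 1 standing higher by a margin that lies beyond the usual scatter of this assay. Within the data shown here, no step between two measured compounds that differ in a single place has been worked out, so the two values themselves are all that can be said of this pair.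

Compound 3, `CC(C)=CCC(=O)C1(O)C(O)=C(CC(C)C)C(=O)C1CC=C(C)C`, has not yet been measured in this assay. It differs from compound 2 in one place: isobutyl in place of isopropyl on a double-bonded ring carbon. Everything else in the two structures is the same. On this change alone, the expected step in this assay is a number 0.45 log units higher from compound 2 to compound 3 (beyond the scatter), an upward move that should exceed the usual scatter but fall well short of the gap seen between compound 1 and compound 2. Compound 3 is therefore estimated at 2.5 in this assay, with a range from 2.1 to 2.9.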

Compound 3, partition coefficient: 2.87
Compound 3: the middle estimate sits 0.37 log units below what was measured; the range from low to high includes it.
By their numbers in this assay, from the lowest: compound 2; then compounds 3 and 1 (each within the scatter of the next).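

In this assay, among these compounds, the exchange of isopropyl for isobutyl on a double-bonded ring carbon gives a number 0.82 log units higher from compound 2 to compound 3 (beyond the scatter) as the first step read between compounds that differ in one place, and it shows that the number at this position answers to the group placed there. The change itself is small on paper, since 3 heavy atoms give way to 4, all carbon, with no ring, no hydrogen-bond donors or acceptors and no net charge on either side, yet the step is printed as beyond the scatter. Nothing available accounts for the size of this step.

Only isopropyl and isobutyl are shown at this position, so it remains open whether a longer chain such as pentyl would raise the number further, or how an amine or a carboxylic acid in the same place would read. From the compounds shown here alone, it also remains open whether the same exchange would give a step of similar size on another core, such as the core of compound 1.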